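Bromo to Iodo in a Growth Inhibitor Series

The source may hold more compounds than are shown below. What is called first, only, known or untested is meant among the compounds shown, and "the series" means these compounds.

Going by the values given here, in a functional assay on K562 cells (Homo sapiens) for inhibition, read by sulforhodamine B assay, with a stated time of 48 h (a lower number here means a stronger inhibitor of growth, a higher number a weaker inhibitor of growth), compound 2 `NC(=O)c1cc(Br)ccc1NC(=O)/C=C/c1ccccc1` gives 415 nM, the lower of the two numbers so far, while compound 1 `Cc1ccc(NC(=O)/C=C/c2ccccc2)c(C(N)=O)c1` gives 1110 nM. Compound 3 `NC(=O)c1cc(I)ccc1NC(=O)/C=C/c1ccccc1` has iodo in place of bromo on an aromatic carbon, meta to a carbamoyl group: iodo in place of bromo on an aromatic carbon. Among the compounds with values here, one measured step bears on this change, the replacement of methyl by bromo at that same place, which gave a 2.7-fold lower number from compound 1 to compound 2 (0.43 log units; beyond the scatter). Within the data shown here, that modest step involves a different pair of groups and is the only guide, so it supports only a weak expectation. A small further move towards a lower number in this assay is expected, probably not beyond the scatter. The expected step is a 1.3-fold lower number from compound 2 to compound 3 (0.11 log units; within the scatter). The estimate for compound 3 is 320 nM, with an expected range from 150 nM to 700 nM.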

Compound 3, concentration for 50% growth inhibition: 920 nM
The estimate for compound 3 lay 2.9-fold (0.46 log units) below the measured number, and the stated range ends below it.
By their numbers in this assay, from the lowest: compound 2; then compounds 3 and 1 (each within the scatter of the next).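

In this assay, the change from bromo to iodo at this place, meta to a carbamoyl group, gave a 2.2-fold higher number from compound 2 to compound 3 (0.35 log units; beyond the scatter), so the drop seen on going from methyl to bromo did not carry on to the next halogen. Iodo in place of methyl gave a 1.2-fold lower number from compound 1 to compound 3 (0.08 log units; within the scatter), which leaves these two groups level at this place, with bromo alone standing apart, so the number does not run in one direction through the three groups. Nothing available here accounts for this turn.

On these data alone, whether chloro or fluoro at this place would fall with bromo or with methyl and iodo remains open. So does the standing of groups of another kind here, such as an amine or methoxy, and whether bromo would keep its place if the carbamoyl group gave way to a carboxylic acid.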